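The source may report more compounds than this note shows. Statements on the series, on what has been measured and on what is new or still open speak of the compounds shown alone.

Three compounds share one core and differ only in the group carried on an amine nitrogen in a ring. Compound 1, `Nc1scc(CN2CCN(C3CCCCC3)CC2)c1C(=O)c1ccc(Cl)cc1`, gives 1.9 nM in an assay on CHO cells for displacement of a labelled ligand from adenosine receptor A1 (Homo sapiens); on this read-out higher numbers stand for weaker binding and lower numbers for tighter binding. Compound 2, `Nc1scc(CN2CCN(c3ccc(F)cc3)CC2)c1C(=O)c1ccc(Cl)cc1`, gives 1.8 nM in this assay, and compound 3, `Nc1scc(CN2CCN(c3ccc(Cl)cc3)CC2)c1C(=O)c1ccc(Cl)cc1`, gives 1.8 nM. Compound 1 carries the highest of these three numbers, yet each gap to it is within the scatter: a 1.1-fold lower number from compound 1 to compound 2 (0.02 log units; within the scatter), a 1.1-fold lower number from compound 1 to compound 3 (0.02 log units; within the scatter), and no change at the digits printed from compound 2 to compound 3 (within the scatter).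

Compound 4, `Nc1scc(CN2CCN(c3ccc(C(F)(F)F)cc3)CC2)c1C(=O)c1ccc(Cl)cc1`, has not yet been measured. It differs from compound 1 in one place: 4-(trifluoromethyl)phenyl in place of cyclohexyl on an amine nitrogen in a ring. Within the data shown here, two measured steps bear on this change, since both also replace cyclohexyl at the same amine nitrogen with a substituted phenyl ring, and both stayed within the scatter. The expected step from compound 1 to compound 4 is therefore none beyond the scatter, namely no change at the digits printed from compound 1 to compound 4 (within the scatter). Compound 4 is estimated to give 1.9 nM in this assay, with a range from 1 nM to 3.8 nM.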

Compound 4, dissociation constant: 1.9 nM
Compound 4: middle estimate and measured number agree at the digits printed; measured number inside the range.
By their numbers in this assay, from the lowest: compounds 2, 3, 1 and 4 (each within the scatter of the next).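

In this assay, the group on the amine nitrogen can grow from cyclohexyl to 4-(trifluoromethyl)phenyl, and the larger group still gives (no change at the digits printed from compound 1 to compound 4 (within the scatter)). Changing the group on the aromatic carbon shows the same flat picture, both for chloro (a 1.1-fold higher number from compound 3 to compound 4 (0.02 log units; within the scatter)) and for fluoro (a 1.1-fold higher number from compound 2 to compound 4 (0.02 log units; within the scatter)), so trifluoromethyl adds a third group on that carbon with no step beyond the scatter. Nothing available explains why these numbers stay so close.

All the groups shown on this nitrogen are rings of carbon only, so it remains open whether the numbers would stay this close with a carboxylic acid, an amine or a longer chain there. Also open, going by these compounds, is what a hydroxyl or a nitrile would do on the aromatic carbon that bears trifluoromethyl in compound 4.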